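Methyl in place of ethoxy, compound 1 to compound 4

The source may report more compounds than this note shows. Statements on the series, on what has been measured and on what is new or still open speak of the compounds shown alone.

Compound 1 `CCOC(=O)c1cccc(-c2ccc(OCC)cc2)c1` was tested in an assay on COS-7 cells for inhibition of patatin-like phospholipase domain-containing protein 2 (Mus musculus) (on this read-out higher numbers stand for weaker inhibition and lower numbers for stronger inhibition), and gives 50000 nM. Compound 2 `CCOC(=O)c1ccc(-c2ccc(OCC)cc2)o1` gives 50000 nM, level with compound 1 at the digits shown, and together these two are the lowest of the three numbers. Compound 3 `CCOC(=O)c1cccc(-c2cccs2)c1` gives 90000 nM, a gap from compound 1 that lies within the scatter, so no order among the three can be read. Compound 4 `CCOC(=O)c1cccc(-c2ccc(C)cc2)c1` differs from compound 1 by methyl in place of ethoxy on an aromatic carbon. Among the compounds with values here, no measured pair carries this change, so no step can be drawn from the numbers. Because compound 1 gives 50000 nM and nothing in the set points elsewhere, the expected step is a 1.2-fold higher number from compound 1 to compound 4 (0.08 log units; within the scatter), none beyond the scatter. Compound 4 is expected to give about 60000 nM, with a range from 25000 nM to 150000 nM.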

Compound 4, half-maximal inhibitory concentration: 140000 nM
For compound 4 the middle estimate is 2.3-fold (0.37 log units) below the measured one, within the range that was stated.
By their numbers in this assay, from the lowest: compounds 1, 2, 3 and 4 (each within the scatter of the next, the first and the last beyond it).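

Methyl in place of ethoxy on this aromatic carbon, para to a large group, gives the first step in the series that lies beyond the scatter, with a 2.8-fold higher number from compound 1 to compound 4 (0.45 log units; beyond the scatter) in this assay. This position therefore responds to the group it carries, and inhibition is weaker with methyl than with ethoxy. Nothing measured here accounts for the step.

As far as these compounds go, whether a longer chain such as propoxy or butoxy, or an amine, at this position would give a lower number than compound 1 remains open. So does whether the same change would give a similar step on the core of compound 2.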